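Thiophen-3-yl to 1H-Pyrazol-4-yl: an Expected Large Rise

The source may hold more compounds than are shown below. What is called first, only, known or untested is meant among the compounds shown, and "the series" means these compounds.

Compound 1 `CCN(C(=O)COc1ccc(C)cc1)C(C)c1cccs1`: "not active" (no number reported)
Compound 2 `CCN(Cc1cc[nH]c1)C(=O)COc1ccc(C)cc1`: 21800 nM
Compound 3 `CCN(Cc1ccsc1)C(=O)COc1ccc(C)cc1`: 88 nM

In an assay on HEK293 cells for agonist activity at transient receptor potential cation channel subfamily M member 8 (Homo sapiens), read by fluorescence and calcium flux, with a stated time of 15 min (on this read-out lower numbers stand for an effect already at smaller amounts and higher numbers for an effect only at larger amounts of compound), compound 3 holds the lowest of the two numbers given; compound 2 lies far higher, and compound 1 is reported without a number. Compound 4 `CCN(Cc1cn[nH]c1)C(=O)COc1ccc(C)cc1` differs from compound 3 by 1H-pyrazol-4-yl in place of thiophen-3-yl on a saturated chain carbon bound to an amide-type nitrogen. Among the measured compounds shown here, the one step that bears on this is a 250-fold lower number from compound 2 to compound 3 (2.39 log units; beyond the scatter), where 1H-pyrrol-3-yl, a ring with a nitrogen carrying hydrogen, gave way to thiophen-3-yl. Since 1H-pyrazol-4-yl again carries such a nitrogen, a large step upward is expected for compound 4, estimated as a 170-fold higher number from compound 3 to compound 4 (2.23 log units; beyond the scatter) because a 250-fold lower number from compound 2 to compound 3 (2.39 log units; beyond the scatter) ran the other way. Compound 4 is therefore expected to give 15000 nM, in the range 2000 nM to 100000 nM.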

Compound 4, half-maximal effective concentration: "active" (no number reported)
Compound 4 has no reported number here; no gap can be computed for the estimate.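

In this assay, among the compounds shown here, compound 4 gives "active" (no number reported) and no step from compound 3 can be read. No measurement shown accounts for this result. As far as these compounds go, how far compound 4 lies from compound 3 stays open.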